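This account rests on a few compounds, and the source may have more. Where it says the series, first, only, none or still open, it means among the compounds named here.

Measured in a functional assay on MOLT-4 cells (Homo sapiens) for cytotoxicity, read by MTT assay; a higher number here means a weaker inhibitor, a lower number a stronger inhibitor:
compound 1 `OCc1c(O)c(Cl)cc(O)c1Cc1cc(O)ccc1O` gives 58100 nM;
compound 2 `COCc1cc(O)cc(Cl)c1O` gives 64700 nM.

Compound 2 has the highest of these two numbers, but its nearest neighbour, compound 1, lies within the scatter of it, so the two cannot be told apart. Compound 3 `COCc1cc(O)ccc1O` differs from compound 2 in one place: hydrogen in place of chloro on an aromatic carbon. Removing a single chlorine from a weakly acting phenol is expected to change little; if anything, the number is expected to move up by a step of a 1.4-fold higher number from compound 2 to compound 3 (0.14 log units; within the scatter), close to the scatter. Compound 3 is therefore estimated at 90000 nM, with a likely range from 30000 nM to 300000 nM.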

Compound 3, half-maximal inhibitory concentration: 86200 nM
For compound 3 the middle estimate is 1.0-fold (0.02 log units) above the measured one; the measured number falls inside the stated range.
By their numbers in this assay, from the lowest: compounds 1, 2 and 3 (each within the scatter of the next).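

For the compounds shown here, compounds 2 and 3 are the first pair here that differ in one place, and in this assay hydrogen in place of chloro gives a 1.3-fold higher number from compound 2 to compound 3 (0.12 log units; within the scatter) at this carbon, ortho to a hydroxy group. At this position, then, the chloro group can be absent without a shift that stands clear of the scatter. No measurement on hand explains this result.

Going by these compounds, whether an amine or a carboxylic acid on this same carbon would move the number remains open. Also open, on these data alone, is whether a longer chain in place of the methoxymethyl group would matter.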